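Halogen swap on the triazole aryl of a terpenoid ester

The source may hold more compounds than are shown below. What is called first, only, known or untested is meant among the compounds shown, and "the series" means these compounds.

Compound 1, `C/C(=C\CC/C(C)=C/CC[C@@H]1[C@@]2(C)CCC(=O)C(C)(C)[C@H]2CC[C@@]1(C)O)CC/C=C(\C)C(=O)OCc1cn(-c2ccc(F)c(Cl)c2)nn1`: > 150000 nM
Compound 2, `C/C(=C\CC/C(C)=C/CC[C@@H]1[C@@]2(C)CCC(=O)C(C)(C)[C@H]2CC[C@@]1(C)O)CC/C=C(\C)C(=O)OCc1cn(-c2cccc(Br)c2)nn1`: > 150000 nM

In a functional assay on A549 cells (Homo sapiens) for antiproliferative activity, read by MTT assay, with a stated time of 48 h (a lower number here means a stronger inhibitor, a higher number a weaker inhibitor), compound 1 reaches only the limit > 150000 nM. Compound 2 likewise gives only the limit > 150000 nM. The step that the two limits leave unreadable from compound 1 to compound 2 cannot be sized because of the limit of > 150000 nM in this assay, at which 2 of the 2 values shown sit. Compound 3, `C/C(=C\CC/C(C)=C/CC[C@@H]1[C@@]2(C)CCC(=O)C(C)(C)[C@H]2CC[C@@]1(C)O)CC/C=C(\C)C(=O)OCc1cn(-c2cccc(F)c2)nn1`, differs from compound 2 by fluoro in place of bromo on an aromatic carbon. Going by the values given here, the one measured step touches the same ring but gives no readable size, so no direction beyond the scatter can be expected. Compound 3 is estimated to sit at the same limit, with an expected value of 200000 nM (range 100000 nM to 600000 nM). The expected step that the limit leaves unreadable from compound 2 to compound 3 is therefore no readable change.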

Compound 3, half-maximal inhibitory concentration: 124000 nM
The estimate for compound 3 lay 1.6-fold (0.21 log units) above the measured number, and the stated range covers the measured number.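

Compound 3 gives a real number in this assay, so a change on this ring can now be given a lower bound. Fluoro in place of bromo gives an at least 1.2-fold lower number from compound 2 to compound 3 (0.08 log units; that floor lies within the scatter), and 3-fluorophenyl in place of 3-chloro-4-fluorophenyl gives an at least 1.2-fold lower number from compound 1 to compound 3 (0.08 log units; that floor lies within the scatter). Each step is only a floor, set by a limit and not by a number: the limit of > 150000 nM in this assay, at which 2 of the 3 values shown sit.

On these data alone, the true size of either step stays open, so a real effect of fluoro cannot be told from scatter. Also open, as far as these compounds go, is whether an amine or a carboxylic acid on this ring would give a clearly lower number.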